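This account rests on a few compounds, and the source may have more. Where it says the series, first, only, none or still open, it means among the compounds named here.

Compound 1 `N/C(=N\NC(=S)N1CCN(c2ccccn2)CC1)c1ccc(F)cn1` gives 77.3% in a functional assay on HeLa cells (Homo sapiens) for cytotoxicity, read by MTT assay, with a stated time of 72 h, tested at 3 uM (a lower number here means less inhibition of growth, a higher number more inhibition of growth at the concentration tested), and stands highest of the two numbers measured. Compound 2 `Cc1cccc(/C(N)=N/NC(=S)N2CCCC2)n1` gives 56.8% in this assay, a value lower than that of compound 1 by a margin beyond the usual scatter. Compound 3 `Cc1ccnc(/C(N)=N/NC(=S)N2CCN(c3ccccn3)CC2)c1` remains to be measured. It differs from compound 1 in one place: 4-methylpyridin-2-yl in place of 5-fluoropyridin-2-yl on a carbon with a double bond to nitrogen. Among the compounds with values here, no measured pair isolates this change, so the expected step is small, downward or none beyond the scatter, estimated as a number 7.3 percentage points lower from compound 1 to compound 3 (within the scatter). Compound 3 is therefore expected to give about 70%, within a range of 50% to 85%.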

Compound 3, percent growth inhibition at one concentration: 42.5%
For compound 3 the middle estimate is 27.5 percentage points above the measured one; measured number outside the range, below it.
By their numbers in this assay, from the lowest: compound 3; then compound 2; then compound 1.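

In this assay the group on a carbon with a double bond to nitrogen is a sensitive place: 4-methylpyridin-2-yl in place of 5-fluoropyridin-2-yl gives a number 34.8 percentage points lower from compound 1 to compound 3 (beyond the scatter), even though the two groups have the same heavy-atom, donor and acceptor counts. So a swap that leaves these counts unchanged can still move growth inhibition by a large step. Nothing at hand accounts for this step. The compounds shown do not separate loss of the fluorine from gain of the methyl. Going by these compounds, how an unsubstituted pyridin-2-yl or a 5-chloropyridin-2-yl would stand at this place remains open.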